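Carbamate to methylsulfonamide on the side chain

The source may hold more compounds than are shown below. What is called first, only, known or untested is meant among the compounds shown, and "the series" means these compounds.

Compound 1 `CN(C[C@@H]1CCCc2cc(S(=O)(=O)c3cccc(F)c3)ccc21)S(N)(=O)=O`: 3.98 nM
Compound 2 `COC(=O)NC[C@@H]1CCCc2cc(S(=O)(=O)c3cccc(F)c3)ccc21`: 1.59 nM

Of the compounds shown here, two sharing one core have been measured in an assay on isolated protein for displacement of a labelled ligand from 5-hydroxytryptamine receptor 6 (Homo sapiens); on this read-out higher numbers stand for weaker inhibition and lower numbers for stronger inhibition. Compound 1 gives 3.98 nM and compound 2 gives 1.59 nM, the lowest of the two numbers, with the step of a 2.5-fold lower number from compound 1 to compound 2 (0.40 log units; beyond the scatter) standing beyond the scatter. Compound 3 `CN(C[C@@H]1CCCc2cc(S(=O)(=O)c3cccc(F)c3)ccc21)S(C)(=O)=O` has not been measured. It differs from compound 2 in one place: methyl(methylsulfonyl)amino in place of (methoxycarbonyl)amino on a saturated chain carbon bound to a saturated ring carbon. Going by the values given here, the only measured step, from compound 1 to compound 2, replaced a methyl-bearing sulfonamide by a carbamate and lowered the number modestly; the change to compound 3 goes back toward a methyl-bearing sulfonamide, now without a hydrogen-bond donor. On that basis compound 3 is expected to sit close to compound 1, with a step of a 2.2-fold higher number from compound 2 to compound 3 (0.34 log units; beyond the scatter) upward from compound 2. The estimate for compound 3 in this assay is 3.5 nM, with a range from 1.2 nM to 10 nM.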

Compound 3, inhibition constant: 0.398 nM
Estimate against measurement, compound 3: 8.8-fold (0.94 log units) above; measured number below the stated range.
By their numbers in this assay, from the lowest: compound 3; then compound 2; then compound 1.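

In this assay, the position on a saturated chain carbon bound to a saturated ring carbon accepts methyl(methylsulfonyl)amino with a 4.0-fold lower number from compound 2 to compound 3 (0.60 log units; beyond the scatter), so a group with no hydrogen-bond donor gives the lowest number of the three. The sulfonyl sulfur also proves sensitive: methyl in place of amino there gives a 10-fold lower number from compound 1 to compound 3 (1.00 log units; beyond the scatter), the largest step in this set. Nothing measured here accounts for either step.

The change from the carbamate swaps the carbonyl for a sulfonyl and adds a methyl on nitrogen in one move, and a methylsulfonylamino group keeping its nitrogen hydrogen would be needed to separate the two. From the compounds shown here alone, it also remains open whether a longer chain on the sulfur, such as ethyl, or a cyclopropyl ring there would lower the number further.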